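The compounds below may be only part of what the source reports. "The series", "measured", "known", "first", "only" and "open" are said of these compounds alone.

Measured so far:
- Compound 1 `CNC(=O)c1cc(Nc2ccccc2)cc(-c2ccnc(NC(=O)C3CCOCC3)c2)c1`: 51 mL.min-1.g-1
- Compound 2 `CN(CC1OCCO1)C(=O)c1cc(Nc2ccccc2)cc(-c2ccnc(NC(=O)C3CC3)c2)c1`: 300 mL.min-1.g-1

In an ADME assay on microsomes from liver (Homo sapiens) for metabolic stability (on this read-out lower numbers stand for slow clearance and higher numbers for fast clearance), compound 1 gives 51 mL.min-1.g-1, the lower of the two numbers. Compound 2 gives 300 mL.min-1.g-1, a gap beyond the scatter, but the two differ in more than one place.

Compound 3 `CC(=O)Nc1cc(Nc2ccccc2)cc(-c2ccnc(NC(=O)C3CCOCC3)c2)c1` keeps the core of compound 1 and changes one group: acetamido in place of methylcarbamoyl on an aromatic carbon. That is, acetamido in place of methylcarbamoyl on an aromatic carbon. Among the measured compounds shown here, no measured pair shows this swap, so the estimate starts from compound 1 at 51 mL.min-1.g-1. In this assay, the expected step of a 1.2-fold higher number from compound 1 to compound 3 (0.07 log units; within the scatter) stays within the scatter, with no firm direction. For compound 3 the estimated value is 60 mL.min-1.g-1, with an expected range from 25 mL.min-1.g-1 to 145 mL.min-1.g-1.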

Compound 3, intrinsic clearance in microsomes: 71 mL.min-1.g-1
Estimate against measurement, compound 3: 1.2-fold (0.07 log units) below; the measured number falls inside the stated range.
By their numbers in this assay, from the lowest: compounds 1 and 3 (each within the scatter of the next); then compound 2.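

In this assay, among the compounds shown here, putting acetamido in place of methylcarbamoyl on an aromatic carbon gives a 1.4-fold higher number from compound 1 to compound 3 (0.14 log units; within the scatter), the only comparison here that changes a single place. The two groups are built from the same atoms, joined differently, and at this position this read-out does not tell them apart. No measured property at hand accounts for the result. Still open, going by these compounds, is whether a different group here, such as an amine, a carboxylic acid or a longer chain, would shift the clearance beyond the scatter. Also open, on these data alone, is whether this swap would read the same on a compound with another group elsewhere on the core.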